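This account rests on a few compounds, and the source may have more. Where it says the series, first, only, none or still open, it means among the compounds named here.

Of the compounds shown here, three built on closely related cores have been tested in a functional assay on T47D cells (Homo sapiens) for cytotoxicity, read by MTT assay, with a stated time of 2 days; a lower number here means a stronger inhibitor, a higher number a weaker inhibitor. Compound 1 `COc1cccc(-c2nc3ccc(C)cc3c(=O)[nH]2)c1` carries a methoxy group on its pendant ring, while compound 2 `Cc1ccc2nc(-c3cccc(F)c3)[nH]c(=O)c2c1` carries a fluoro group there instead. Compound 3 `Cc1ccc2c(=O)[nH]c(-c3cccc(F)c3)nc2c1` is made of the same atoms as compound 2 joined differently; the difference between the two cores is not broken down here. In this assay compound 1 reaches only a limit of the assay, > 50000 nM. Compound 2 likewise gives only a limit, > 50000 nM. Compound 3 also comes out at a limit, > 50000 nM. The change from compound 2 to compound 1 is methoxy in place of fluoro on an aromatic carbon and it produced a step that the two limits leave unreadable from compound 2 to compound 1, unreadable because of the limit of > 50000 nM in this assay, at which 3 of the 3 values shown sit. Compound 4 `COc1cccc(-c2nc3cc(C)ccc3c(=O)[nH]2)c1`, not yet measured, arises from compound 3 by the same change, (methoxy in place of fluoro on an aromatic carbon). Within the data shown here, since no measured compound gives a number, the step from compound 3 to compound 4 is expected to be a step that the limit leaves unreadable from compound 3 to compound 4, an expectation resting only on a step that the two limits leave unreadable from compound 2 to compound 1. Compound 4 is therefore estimated to come out around 60000 nM, most likely again as a limit rather than a number.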

Compound 4, half-maximal inhibitory concentration: > 50000 nM
Compound 4: only a limit was reported; the forecaster's own chance of this, stated with the estimate: 85%; the middle value lies beyond the limit too.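

No new step can be read between compound 3 and compound 4, because neither gives a number, only a limit: the limit of > 50000 nM in this assay, at which 4 of the 4 values shown sit. The compounds shown leave open whether methoxy and fluoro on the pendant ring differ at all in this assay, and whether any of these four compounds would give a measurable value there.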